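This account rests on a few compounds, and the source may have more. Where it says the series, first, only, none or still open, it means among the compounds named here.

Compound 1 `CCCc1nc(-c2ccccc2)c(CNCCCN2CCN(c3cccc(Cl)c3)CC2)o1` gives 65.9% in an assay on HEK293 cells for inhibition of Voltage-dependent T-type calcium channel subunit alpha-1G (Homo sapiens), read by fluorescence, tested at 10 uM; a higher number here means more inhibition at the concentration tested (going by the name of the read-out), a lower number less inhibition.
Compound 2 `CCCc1nc(-c2ccccc2)c(CNCCCN2CCN(c3ccc(C(F)(F)F)cc3)CC2)o1` gives 51.6% in this assay.

Going by the values given here, compound 2 stands lowest of the two numbers; its nearest neighbour is compound 1, and the single measured step, a number 14.3 percentage points lower from compound 1 to compound 2 (beyond the scatter), lies beyond the scatter. Compound 3 `CCCc1nc(-c2ccccc2)c(CNCCCN2CCN(c3ccc(Cl)cc3)CC2)o1` has not been measured. It differs from compound 2 in one place: chloro in place of trifluoromethyl on an aromatic carbon. Among the compounds with values here, only the step from compound 1 to compound 2 bears on this change, and only partly: that step changed both the group and its position on the ring, whereas here only the group changes. That step was modest. A return of part of that loss seems plausible, but it may not exceed the scatter. Compound 3 is expected to move by a number 8.4 percentage points higher from compound 2 to compound 3 (within the scatter). Compound 3 is estimated at 60%, with a range from 45% to 75%.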

Compound 3, a percentage reported as inhibition, at one concentration (the size of the read-out at that concentration, not a potency): 63.3%
Compound 3: the middle estimate sits 3.3 percentage points below what was measured, within the range that was stated.
By their numbers in this assay, from the lowest: compound 2; then compounds 3 and 1 (each within the scatter of the next).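

Held at the same place on the ring, the exchange of trifluoromethyl for chloro alone shifts the reading in this assay (a number 11.7 percentage points higher from compound 2 to compound 3 (beyond the scatter)), so the group itself matters here, a point the earlier step could not separate from the change of position. Moving the chlorine leaves no difference that can be read (a number 2.6 percentage points lower from compound 1 to compound 3 (within the scatter)), so 4-chlorophenyl and 3-chlorophenyl are not told apart in this assay, and the earlier drop now tracks the trifluoromethyl group rather than the position. No measurement offered here accounts for this difference between chloro and trifluoromethyl.

The compounds shown leave open how a methoxy group, a nitrile or a fluoro group would read at this place. Going by these compounds, each reading also comes from a single concentration, so how the three compounds compare in potency remains unknown.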